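The source may hold more compounds than are shown below. What is called first, only, known or untested is meant among the compounds shown, and "the series" means these compounds.

Measured compounds in this series:

- compound 1 `O=C(COc1cccc2ccccc12)N/N=C/c1ccc(Cl)cc1` gives 100 ug/mL in an ADME assay on HEL cells (Homo sapiens) for cytotoxicity; a lower number here means that less compound is tolerated, a higher number that more compound is tolerated
- compound 2 `C/C(=N\NC(=O)COc1cccc2ccccc12)c1ccccc1` gives 20 ug/mL in this assay
- compound 3 `C/C(=N\NC(=O)COc1cccc2ccccc12)c1ccccc1Br` gives 20 ug/mL in this assay

Compound 1 stands highest of the three numbers. Compounds 2 and 3 sit together at a lower value, and the gap from either of them up to compound 1 is beyond the scatter, so compound 1 is the one tolerated at the highest concentration in this set.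

For the measured compounds named here, only one step has both ends measured: no change at the digits printed from compound 2 to compound 3 (within the scatter). It is the nearest guide here, as it also brings a bromo group onto an aromatic carbon, there in place of hydrogen, and leaves the read-out unchanged.

Compound 4 `O=C(COc1cccc2ccccc12)N/N=C/c1ccc(Br)cc1` differs from compound 1 by bromo in place of chloro on an aromatic carbon. That swap of one halogen for another is a smaller alteration than the hydrogen-to-bromo step seen between compound 2 and compound 3, which itself produced no shift. For compound 4 the expectation is therefore no step beyond the scatter, no change at the digits printed from compound 1 to compound 4 (within the scatter). Compound 4 is estimated at 100 ug/mL, with a range from 50 ug/mL to 200 ug/mL.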

Compound 4, minimum cytotoxic concentration: > 100 ug/mL
Compound 4: a limit, no number (the forecaster's own chance of this, stated with the estimate: 20%); the middle value lies on the limit itself.
By their numbers in this assay, from the lowest: compounds 2 and 3 (each within the scatter of the next); then compound 1.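

In this assay compound 4 gives > 100 ug/mL, which is a limit of the assay and not a number. For the compounds shown here, the change from 4-chlorophenyl to 4-bromophenyl reads as a number no lower from compound 1 to compound 4 (the limit leaves the size open), the first reading of a halogen swap at this place, on an aromatic carbon para to a large group, and unlike the earlier bromo step, no change at the digits printed from compound 2 to compound 3 (within the scatter), it rests on the core of compound 1. The size of the new step cannot be read, and the top of the reported range now holds one compound of the series: the limit of > 100 ug/mL in this assay, at which 1 of the 4 values shown sits.

Going by these compounds, whether an amine, a carboxylic acid or a methoxy group at this same place would keep the tolerated concentration of the two halogen compounds stays open. Also open, on these data alone, is how a plain phenyl, with hydrogen at this place on the same core, would compare with compound 1 and compound 4.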